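The compounds below may be only part of what the source reports. "The series", "measured", "known", "first", "only" and "open" are said of these compounds alone.

Measured so far:
compound 1, `CN(C)c1ccc(/C=C(/SCc2ccc(Cl)cc2Cl)C(=O)c2ccc(Cl)cc2)cc1` — 50000 nM in a functional assay on DU-145 cells (Homo sapiens) for inhibition, read by trypan blue exclusion, with a stated time of 96 h; a lower number here means a stronger inhibitor of growth, a higher number a weaker inhibitor of growth
compound 2, `Cc1ccc(S(=O)(=O)/C(=C/c2ccc(C)s2)C(=O)c2ccc(Cl)cc2)cc1` — 50000 nM in this assay
compound 3, `Cc1ccc(S(=O)(=O)/C(=C/c2ccc(Oc3ccccc3)cc2)C(=O)c2ccc(Cl)cc2)cc1` — 1000 nM in this assay

Among these three, compound 3 stands lowest, and its gap to both compound 1 and compound 2 lies beyond the usual scatter, so on these numbers it is the strongest growth inhibitor of the set. Compound 4, `Cc1ccc(S(=O)(=O)/C(=C/c2ccc(N(C)C)cc2)C(=O)c2ccc(Cl)cc2)cc1`, differs from compound 3 in one place: dimethylamino in place of phenoxy on an aromatic carbon. Going by the values given here, no step between measured compounds shows this exchange directly. Compound 1 also carries dimethylamino on a ring, yet with a different core, and its value is high, which argues for a step upward. Compound 4 is expected to lose potency, with a 10-fold higher number from compound 3 to compound 4 (1.00 log units; beyond the scatter), giving an estimated 10000 nM (range 1500 nM to 50000 nM).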

Compound 4, concentration for 50% growth inhibition: > 100000 nM
Compound 4: only a limit was reported (the forecaster's own chance of this, stated with the estimate: 30%); middle value at least 10-fold (1.00 log units) from the limit.
By their numbers in this assay, from the lowest: compound 3; then compounds 1 and 2 (each within the scatter of the next). At a limit, above all of these: compound 4.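

At this aromatic carbon, para to a large group, dimethylamino in place of phenoxy on an aromatic carbon can now be read directly, and the step is large: an at least 100-fold higher number from compound 3 to compound 4 (2.00 log units; beyond the scatter) in this assay. On these data alone, compound 4 gives only a limit, > 100000 nM, so the full size of this step stays unknown. With an at least 2.0-fold higher number from compound 2 to compound 4 (0.30 log units; that floor lies within the scatter) and with an at least 2.0-fold higher number from compound 1 to compound 4 (0.30 log units; that floor lies within the scatter) the floor stays within the scatter, so neither step can be read as a change.

Open, as far as these compounds go, is what a methoxy, a benzyloxy or a primary amine would give on this carbon, and so whether the step follows the loss of the phenoxy ring or the arrival of dimethylamino.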